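Swapping Fluoro for Bromo in a Series at the Limit

A few compounds are considered here, and "the series" means these few. Any claim that something is new, unique, unknown or untested is made for them only; others in the source may bear on it.

Of the compounds shown here, three sharing one core have been tested in a functional assay on MDA-MB-231 cells (Homo sapiens) for cytotoxicity, read by MTT assay, with a stated time of 48 h; a higher number here means a weaker inhibitor, a lower number a stronger inhibitor. Compound 1 `Fc1cccc(-c2nc(Nc3ccccc3)c3ccccc3n2)c1` reaches only the assay limit, > 50000 nM. Compound 2 `Fc1cccc(-c2nc(Nc3ccccc3F)c3cc(F)ccc3n2)c1` likewise gives only a limit, > 50000 nM. Compound 3 `Fc1cccc(-c2nc(Nc3ccc(Br)cc3)c3cc(F)ccc3n2)c1` also stops at a limit, > 50000 nM. Between these two limits, a step that the two limits leave unreadable from compound 2 to compound 3. The change leading to compound 4 `Fc1cccc(-c2nc(Nc3ccccc3Br)c3cc(F)ccc3n2)c1` is bromo in place of fluoro on an aromatic carbon. For the measured compounds named here, no measured step can be sized, and every value shown sits at the limit of > 50000 nM in this assay, at which 3 of the 3 values shown sit, so no movement beyond the scatter in this assay can be read from the data, and a further limit is the most likely outcome. Compound 4 is expected to give 60000 nM, lying between 25000 nM and 200000 nM. The expected step is a step that the limit leaves unreadable from compound 2 to compound 4.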

Compound 4, half-maximal inhibitory concentration: > 50000 nM
Compound 4: only a limit was reported; the forecaster's own chance of this, stated with the estimate: 85%; the middle value lies beyond the limit too.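

No step from compound 2 or compound 3 to compound 4 can be read, since compound 4 also gives only a limit: the limit of > 50000 nM in this assay, at which 4 of the 4 values shown sit.

Going by these compounds, whether any change to the shared core gives a measurable value in this assay remains open.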